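A few compounds are considered here, and "the series" means these few. Any claim that something is new, unique, unknown or untested is made for them only; others in the source may bear on it.

Compound 1 `CC(Oc1ccc(Oc2ccc(C(F)(F)F)cc2)cc1)C(=O)Cn1nnc(-c2ccccc2)n1` is the starting point of this small set. In an assay on microsomes from brain for inhibition of Fatty-acid amide hydrolase 1 (Rattus norvegicus), read by fluorescence and HPLC, with a stated time of 60 min (on this read-out lower numbers stand for stronger inhibition and higher numbers for weaker inhibition), compound 1 gives 160 nM. Compound 2 `CC(Oc1ccc(-c2ccccc2)cc1)C(=O)Cn1nnc(-c2ccccc2)n1` differs from it by phenyl in place of 4-(trifluoromethyl)phenoxy on an aromatic carbon, and in this assay compound 2 gives 15 nM, a step of an 11-fold lower number from compound 1 to compound 2 (1.03 log units; beyond the scatter). Compound 3 `COC(=O)c1ccc(-c2nnn(CC(=O)C(C)Oc3ccc(Oc4ccc(C(F)(F)F)cc4)cc3)n2)cc1` has a different core, set apart from compound 1 by methoxycarbonyl in place of hydrogen on an aromatic carbon; in this assay compound 3 gives 130 nM, a step of a 1.2-fold lower number from compound 1 to compound 3 (0.09 log units; within the scatter). Compound 4 `COC(=O)c1ccc(-c2nnn(CC(=O)C(C)Oc3ccc(-c4ccccc4)cc3)n2)cc1` has not been measured. It differs from compound 3 by phenyl in place of 4-(trifluoromethyl)phenoxy on an aromatic carbon, the same change at the same place that carried compound 1 to compound 2. A step of similar size is expected, an 11-fold lower number from compound 3 to compound 4 (1.03 log units; beyond the scatter), because the earlier step of an 11-fold lower number from compound 1 to compound 2 (1.03 log units; beyond the scatter) was large, though this rests on a single pair. Compound 4 is therefore estimated at 12 nM in this assay, between 5 nM and 30 nM.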

Compound 4, half-maximal inhibitory concentration: 23 nM
Estimate against measurement, compound 4: 1.9-fold (0.28 log units) below, within the range that was stated.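

In this assay, putting phenyl in place of 4-(trifluoromethyl)phenoxy on the core that carries methoxycarbonyl gives a 5.7-fold lower number from compound 3 to compound 4 (0.75 log units; beyond the scatter), and this step agrees with the one on the core of compound 1: the same change on two cores in this assay, an 11-fold lower number (1.03 log units; beyond the scatter) from compound 1 to compound 2 and a 5.7-fold lower number (0.75 log units; beyond the scatter) from compound 3 to compound 4, 1.9-fold (0.28 log units) apart, within the scatter of two such steps. Adding methoxycarbonyl to the phenyl compound gives a 1.5-fold higher number from compound 2 to compound 4 (0.19 log units; within the scatter), which agrees with the same addition made to compound 1: the same change on two cores in this assay, a 1.2-fold lower number (0.09 log units; within the scatter) from compound 1 to compound 3 and a 1.5-fold higher number (0.19 log units; within the scatter) from compound 2 to compound 4, 1.9-fold (0.28 log units) apart, within the scatter of two such steps. So the phenyl change carried over between these two cores in this assay, but two pairs say nothing about any other core, or about why the number falls.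

From the compounds shown here alone, it remains open whether a carboxylic acid in place of the methoxycarbonyl, or an amine on the same ring, would fit this pattern.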